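Compound 1 to compound 4 at the cytotoxicity limit

The source may report more compounds than this note shows. Statements on the series, on what has been measured and on what is new or still open speak of the compounds shown alone.

Measured so far in an ADME assay on HepG2 cells (Homo sapiens) for cytotoxicity, in the presence of a further agent that is not named here; a lower number here means a stronger inhibitor, a higher number a weaker inhibitor:
compound 1 `CC(NC(=O)c1nc(Cc2ccccc2C(F)(F)F)n(C)c(=O)c1O)c1ccccc1` gives > 100000 nM (a limit)
compound 2 `COc1nc(C(C)c2ccccc2C(F)(F)F)nc(C(=O)NCc2ccccc2)c1O` gives > 100000 nM (a limit)
compound 3 `Cn1c(Cc2ccccc2C(F)(F)F)nc(C(=O)NCc2ccccc2F)c(O)c1=O` gives > 100000 nM (a limit)

Compound 1 gives > 100000 nM in this assay as a limit and not as a number. Among the compounds with values here, the whole series so far reads the limit of > 100000 nM in this assay, at which 3 of the 3 values shown sit, and so gives no numerical position for compound 1 within it.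

Not yet measured is compound 4 `Cn1c(Cc2ccccc2C(F)(F)F)nc(C(=O)NCc2ccccc2)c(O)c1=O`, which differs from compound 1 as follows: hydrogen in place of methyl on a saturated chain carbon bound to an amide-type nitrogen and an aromatic carbon. In short, 1-phenylethyl becomes benzyl on the amide-type nitrogen.

Within the data shown here, the one measured step that bears on this, a step that the two limits leave unreadable from compound 1 to compound 3, also replaces 1-phenylethyl, and its size cannot be read.

No step beyond the scatter is expected in this assay because of the limit of > 100000 nM in this assay, at which 3 of the 3 values shown sit, and compound 4 will most likely be reported as a limit too. The expected step is a number no higher from compound 1 to compound 4 (the limit leaves the size open) and it is an estimate only. The estimate for compound 4 is 100000 nM with an expected range from 60000 nM to 200000 nM as its ends.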

Compound 4, half-maximal inhibitory concentration: > 100000 nM
Compound 4 ended at the assay's limit; the forecaster's own chance of this, stated with the estimate: 90%; the middle value sits exactly at the limit.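

In this assay compound 4 gives > 100000 nM, a limit and not a number. The steps from compound 1 and from compound 3 to compound 4 therefore cannot be read: the limit of > 100000 nM in this assay, at which 4 of the 4 values shown sit.

The compounds shown leave open how these four compounds rank in this assay.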